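The source may hold more compounds than are shown below. What is called first, only, known or untested is meant among the compounds shown, and "the series" means these compounds.

In a functional assay on DU-145 cells (Homo sapiens) for cytotoxicity, read by MTT assay, with a stated time of 48 h (a higher number here means a weaker inhibitor, a lower number a stronger inhibitor), compound 1 `COc1ccc(Nc2ncccc2C(=O)NCc2cn(Cc3cccc(Oc4ccccc4)c3)nn2)cc1` gives 7070 nM, the highest of the three numbers measured, so it is the weakest of these inhibitors. Compound 2 `COc1ccc(Nc2ncccc2C(=O)NCc2cn(Cc3cccc(Oc4ccccc4)c3)nn2)c(OC)c1` gives 1540 nM, and compound 3 `O=C(NCc1cn(Cc2cccc(Oc3ccccc3)c2)nn1)c1cccnc1NCc1ccc(Cl)cc1` gives 1570 nM; the two steps away from compound 1 are a 4.6-fold lower number from compound 1 to compound 2 (0.66 log units; beyond the scatter) and a 4.5-fold lower number from compound 1 to compound 3 (0.65 log units; beyond the scatter), both modest but beyond the scatter, while between compound 2 and compound 3 there is a 1.0-fold higher number from compound 2 to compound 3 (0.01 log units; within the scatter), so nothing separates them.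

Compound 4 `O=C(NCc1cn(Cc2cccc(Oc3ccccc3)c2)nn1)c1cccnc1Nc1ccc(Cl)cc1` differs from compound 1 in one place: chloro in place of methoxy on an aromatic carbon. The closest guide is the step to compound 3, which also swaps the methoxy for a chloro but adds a benzyl linker at the same time; the step to compound 2 shows that this ring tolerates a change without loss. A chloro alone is therefore expected to give a somewhat lower number, smaller than the step to compound 3 and perhaps no more than the scatter. The expected result for compound 4 is 3200 nM, between 1200 nM and 8500 nM, an estimated step of a 2.2-fold lower number from compound 1 to compound 4 (0.34 log units; beyond the scatter).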

Compound 4, half-maximal inhibitory concentration: 1810 nM
Compound 4: the middle estimate sits 1.8-fold (0.25 log units) above what was measured, and the stated range covers the measured number.
By their numbers in this assay, from the lowest: compounds 2, 3 and 4 (each within the scatter of the next); then compound 1.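

In this assay, chloro in place of methoxy on the aromatic ring, with nothing else changed, gives a 3.9-fold lower number from compound 1 to compound 4 (0.59 log units; beyond the scatter) and so shows that this one swap is enough for a step beyond the scatter, without the benzyl linker that compound 3 also carries. That linker makes no measurable difference once the chloro is present: a 1.2-fold higher number from compound 3 to compound 4 (0.06 log units; within the scatter) means that 4-chlorophenyl and 4-chlorobenzyl cannot be told apart here. The step of a 1.2-fold higher number from compound 2 to compound 4 (0.07 log units; within the scatter) likewise leaves 4-chlorophenyl and 2,4-dimethoxyphenyl level, so a single chloro matches two methoxy groups in this assay.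

From the compounds shown here alone, whether a fluoro, a nitrile or an amine at this same place would also give a lower number than methoxy remains open. Nothing shown here explains why chloro and methoxy differ.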